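A few compounds are considered here, and "the series" means these few. Any claim that something is new, unique, unknown or untested is made for them only; others in the source may bear on it.

Measured compounds:
compound 1 `CC1=C(C(=O)C2CC2)C(c2ccsc2)NC(=O)N1` — 2%
compound 2 `CC1=C(C(=O)OC2CCCC2)C(c2ccco2)NC(=O)N1` — 1%
compound 3 `CC1=C(C(=O)OC2CCCC2)C(c2cccs2)NC(=O)N1` — 9%

All three were tested in an assay on membranes from CHO cells for displacement of a labelled ligand from adenosine receptor A1 (Homo sapiens), read by scintillation counting, with a stated time of 60 min, tested at 1 uM; on this read-out higher numbers stand for more inhibition at the one concentration tested (going by the name of the read-out) and lower numbers for less inhibition. On this read-out compound 3 gives 9%, and the other two lie within the scatter of it: compound 1 gives 2% and compound 2 gives 1%. None of the three stands apart from another by more than the scatter, so the set shows only weak inhibition throughout.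

Among the measured compounds shown here, the only single-point step among them runs a number 8 percentage points higher from compound 2 to compound 3 (within the scatter) and concerns the aryl group on the saturated ring carbon.

Compound 4 `CC1=C(C(=O)OC2CCCC2)C(c2ccsc2)NC(=O)N1` differs from compound 3 by thiophen-3-yl in place of thiophen-2-yl on a saturated ring carbon. For the measured compounds named here, no measured pair covers this particular exchange; the nearest comparison, the step from compound 2 to compound 3, also altered the aryl group on the same carbon without leaving the scatter. Compound 4 is therefore expected to show no step beyond the scatter, a number 3 percentage points lower from compound 3 to compound 4 (within the scatter). Compound 4 is estimated at 6%, within the range -5% to 20%.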

Compound 4, a percentage reported as inhibition, at one concentration (the size of the read-out at that concentration, not a potency): 5%
For compound 4 the middle estimate is 1 percentage points above the measured one; the range from low to high includes it.
By their numbers in this assay, from the lowest: compounds 2, 1, 4 and 3 (each within the scatter of the next).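

In this assay, thiophen-3-yl in place of thiophen-2-yl on the saturated ring carbon gives a number 4 percentage points lower from compound 3 to compound 4 (within the scatter), so with cyclopentyloxy held fixed, the point of attachment of the thiophene leaves this read-out within the scatter. The exchange of furan-2-yl for thiophen-3-yl at this position gives a number 4 percentage points higher from compound 2 to compound 4 (within the scatter), and the other place on the core, the group on the carbonyl carbon, can now be read as well: cyclopentyloxy in place of cyclopropyl gives a number 3 percentage points higher from compound 1 to compound 4 (within the scatter). No evidence is at hand that bears on these small steps.

As far as these compounds go, what remains open is whether any group on the saturated ring carbon, such as a phenyl or a pyridine ring, would move the number beyond the scatter. The same question stands for a longer chain or an amine in place of cyclopentyloxy on the carbonyl carbon.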